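Methyl for Methoxy: A Small Change in a Weak Series

The source may hold more compounds than are shown below. What is called first, only, known or untested is meant among the compounds shown, and "the series" means these compounds.

Compound 1, `O=C(Nc1cccc(-c2ccccc2)c1)C(Cl)Cl`: 20200 nM
Compound 2, `COc1cccc(-c2cccc(NC(=O)C(Cl)Cl)c2)c1`: 33800 nM

In a functional assay on NCI-H460 cells (Homo sapiens) for cytotoxicity, read by MTT assay, with a stated time of 68 h (on this read-out higher numbers stand for weaker inhibition and lower numbers for stronger inhibition), compound 1 gives 20200 nM, and compound 2 gives 33800 nM, the higher of the two numbers, although the step of a 1.7-fold higher number from compound 1 to compound 2 (0.22 log units; within the scatter) lies within the scatter. Compound 3, `Cc1cccc(-c2cccc(NC(=O)C(Cl)Cl)c2)c1`, carries methyl in place of methoxy on an aromatic carbon. Among the measured compounds shown here, the only step that bears on this is the one from compound 1 to compound 2, which stayed within the scatter, so no step beyond the scatter is expected here either. Compound 3 is therefore estimated at 28000 nM, with a range from 12000 nM to 65000 nM. The expected step is a 1.2-fold lower number from compound 2 to compound 3 (0.08 log units; within the scatter).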

Compound 3, half-maximal inhibitory concentration: 24300 nM
Beside the measured number, compound 3's estimate is 1.2-fold (0.06 log units) above it; the range from low to high includes it.
By their numbers in this assay, from the lowest: compounds 1, 3 and 2 (each within the scatter of the next).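

In this assay the swap of methoxy for methyl gives a 1.4-fold lower number from compound 2 to compound 3 (0.14 log units; within the scatter) and the swap of hydrogen for methyl gives a 1.2-fold higher number from compound 1 to compound 3 (0.08 log units; within the scatter). At this position, meta to a large group, hydrogen, methoxy and methyl therefore all read alike, and even removing the hydrogen-bond acceptor of the methoxy leaves the number within the scatter. Nothing available explains this flat result.

On these data alone, whether an amine or a carboxylic acid here would move the number beyond the scatter stays open. So does the effect of a longer chain such as butyl.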